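A few compounds are considered here, and "the series" means these few. Any claim that something is new, unique, unknown or untested is made for them only; others in the source may bear on it.

Measured so far in an assay on isolated protein for binding affinity to adenosine receptor A1 (Bos taurus); a higher number here means a weaker inhibitor, a lower number a stronger inhibitor:
compound 1, `CCCCCCNc1nc(-c2ccccc2)nc2c1nnn2Cc1ccccc1`, 13200000 nM;
compound 2, `OCCNc1nc(-c2ccccc2)nc2c1nnn2Cc1ccccc1`, 38000000 nM;
compound 3, `CNc1nc(-c2ccccc2)nc2c1nnn2Cc1ccccc1Cl`, 191000000 nM.

Among these three, compound 3 gives the highest number, and its steps to both compound 2 and compound 1 lie beyond the scatter. Among the compounds with values here, the only step between two measured compounds is a 2.9-fold higher number from compound 1 to compound 2 (0.46 log units; beyond the scatter), which concerns the chain on the ring nitrogen and not the benzyl ring.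

Compound 4, `CNc1nc(-c2ccccc2)nc2c1nnn2Cc1ccccc1`, differs from compound 3 as follows: hydrogen in place of chloro on an aromatic carbon. No measured pair in this assay changes the same place, so nothing shown bears directly on this step. The expectation is therefore a step of a 1.3-fold lower number from compound 3 to compound 4 (0.10 log units; within the scatter), not beyond the scatter. Compound 4 is thus estimated at 150000000 nM, within 50000000 nM to 450000000 nM.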

Compound 4, inhibition constant: 353000000 nM
Estimate against measurement, compound 4: 2.4-fold (0.37 log units) below, within the range that was stated.
By their numbers in this assay, from the lowest: compound 1; then compound 2; then compounds 3 and 4 (each within the scatter of the next).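

In this assay, hydrogen in place of chloro on the aromatic carbon, ortho to a large group, gives a 1.8-fold higher number from compound 3 to compound 4 (0.27 log units; within the scatter), so this change does not separate the two compounds. Within the data shown here, with the benzyl group held constant, hydrogen in place of hydroxymethyl on the chain gives a 9.3-fold higher number from compound 2 to compound 4 (0.97 log units; beyond the scatter) and hydrogen in place of pentyl gives a 27-fold higher number from compound 1 to compound 4 (1.43 log units; beyond the scatter), so in this set only the steps at the chain lie beyond the scatter. Nothing shown gives a reason for any of these steps. Going by these compounds, whether a methoxy or a bromo at this place would also stay within the scatter remains open. So does whether chloro would give the same result on compounds carrying the longer chains of compound 1 and compound 2.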